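A few compounds are considered here, and "the series" means these few. Any claim that something is new, unique, unknown or untested is made for them only; others in the source may bear on it.

Three carbamates share one core and differ only in the group on the oxygen next to the carbonyl. Compound 1 `CCOC(=O)N1CCC(Oc2ncnc3c2CCN3c2ccc(S(C)(=O)=O)cc2F)CC1` gives 135% in a functional assay on CHO-K1 cells with Glucose-dependent insulinotropic receptor (Homo sapiens) as the target, read by a luciferase reporter, with a stated time of 5 h; a higher number here means a larger maximal response, a lower number a smaller maximal response. Compound 2 `CCCOC(=O)N1CCC(Oc2ncnc3c2CCN3c2ccc(S(C)(=O)=O)cc2F)CC1` gives 111%, and compound 3 `CC(C)(C)COC(=O)N1CCC(Oc2ncnc3c2CCN3c2ccc(S(C)(=O)=O)cc2F)CC1` gives 80%, the lowest of the three numbers. Each lengthening or branching of that group lowered the response: a number 24 percentage points lower from compound 1 to compound 2 (beyond the scatter), a number 31 percentage points lower from compound 2 to compound 3 (beyond the scatter), and taken together a number 55 percentage points lower from compound 1 to compound 3 (beyond the scatter).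

Compound 4 `CC(C)SC(=O)N1CCC(Oc2ncnc3c2CCN3c2ccc(S(C)(=O)=O)cc2F)CC1` is not yet measured. It differs from compound 3 in one place: isopropylsulfanyl in place of neopentyloxy on a carbonyl carbon. Within the data shown here, the group that enters has fewer heavy atoms than the one that leaves and carries a sulfur where the carbamates carry an oxygen, so none of the measured steps matches it directly; they only show that the smaller groups on this carbonyl gave the larger responses, with compound 3 at the bottom.

Compound 4 is therefore expected to lie above compound 3, by a number 25 percentage points higher from compound 3 to compound 4 (beyond the scatter), an estimate of 105% with a range from 75% to 135%.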

Compound 4, largest response reached (reported as percent of maximum), in percent of the reference or control that the assay uses: 138%
For compound 4 the middle estimate is 33 percentage points below the measured one; measured number above the stated range.
By their numbers in this assay, from the lowest: compound 3; then compound 2; then compounds 1 and 4 (each within the scatter of the next).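

In this assay the change to isopropylsulfanyl gives a number 58 percentage points higher from compound 3 to compound 4 (beyond the scatter) and also a number 27 percentage points higher from compound 2 to compound 4 (beyond the scatter), so the fall seen along the three carbamates does not carry over to this branched, sulfur-linked group. The remaining comparison is a number 3 percentage points higher from compound 1 to compound 4 (within the scatter), which shows that the high response at this carbonyl carbon is not confined to the ethoxy group of the first carbamate. Nothing available here explains why this change behaves as it does.

Sulfur and branching enter together in this change, so the compounds shown cannot say which of the two matters, or whether both do. A compound carrying isopropoxy and another carrying ethylsulfanyl on the same carbonyl carbon would separate the two.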